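A few compounds are considered here, and "the series" means these few. Any claim that something is new, unique, unknown or untested is made for them only; others in the source may bear on it.

Three compounds built on a shared core, each carrying a free acid chain and an amide, have been run through a functional assay on MDA-MB-231 cells (Homo sapiens) for antiproliferative activity, read by MTT assay, with a stated time of 24 h; a lower number here means a stronger inhibitor, a higher number a weaker inhibitor. In this assay compound 1 `O=C(O)CC(NC(=O)c1ccc(F)cc1)c1ccccc1F` gives 72300 nM. Compound 2 `O=C(O)CC(NC(=O)c1cccc(Br)c1)c1ccccc1F` returns > 100000 nM, which is a limit of the assay rather than a number. Compound 3 `O=C(O)CC(NC(=O)c1ccc(F)cc1)c1ccc(Cl)cc1Cl` gives 58300 nM; its number and that of compound 1 lie within the usual scatter of each other, so nothing can be said about which is the stronger inhibitor.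

The change from compound 1 to compound 2 is 3-bromophenyl in place of 4-fluorophenyl on a carbonyl carbon and it brought an at least 1.3-fold higher number from compound 1 to compound 2 (0.14 log units; that floor lies within the scatter). The reading of compound 2 sits at the limit of > 100000 nM in this assay, at which 1 of the 3 values shown sits, so the true size of that step is not known. How the core of compound 3 differs from the core of compound 1 is not broken down here.

Compound 4 `O=C(O)CC(NC(=O)c1cccc(Br)c1)c1ccc(Cl)cc1Cl` is not yet measured in this assay. It differs from compound 3 by 3-bromophenyl in place of 4-fluorophenyl on a carbonyl carbon, the same change as that from compound 1 to compound 2, made at a place described in the same words. Resting on compound 1, whose value is 72300 nM, and on the measured step of an at least 1.3-fold higher number from compound 1 to compound 2 (0.14 log units; that floor lies within the scatter), I expect the step from compound 3 to compound 4 to be a 1.9-fold higher number from compound 3 to compound 4 (0.28 log units; within the scatter). Compound 4 is estimated at 110000 nM, with a likely range from 50000 nM to 300000 nM, and a fair chance that only a limit is reported.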

Compound 4, half-maximal inhibitory concentration: 82500 nM
For compound 4 the middle estimate is 1.3-fold (0.12 log units) above the measured one; the range from low to high includes it.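

In this assay, putting 3-bromophenyl in place of 4-fluorophenyl on the carbonyl carbon of the amide brings a 1.4-fold higher number from compound 3 to compound 4 (0.15 log units; within the scatter), so on this core the change cannot be told apart from the ordinary differences between repeated measurements. Setting this step beside the one made on the core of compound 1 gives a limited comparison: the same change on two cores in this assay, an at least 1.3-fold higher number (0.14 log units; that floor lies within the scatter) from compound 1 to compound 2 and a 1.4-fold higher number (0.15 log units; within the scatter) from compound 3 to compound 4; the limit leaves it open whether they differ. The result shows that the second step can be read as a number and that nothing here points to a large effect on that core, but it does not show that the change has the same size on both cores, and two cores are too few to establish a rule for the series: the limit of > 100000 nM in this assay, at which 1 of the 4 values shown sits.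

The compounds shown leave open what other groups on the aromatic ring of the amide would do, such as a methoxy group, a nitrile or an amine, and whether any of them would move the number beyond the scatter. Also open, going by these compounds, is how the reading would respond if the free carboxylic acid were replaced by its methyl ester, or if the acid sat on a longer chain.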